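An aromatic amine at the end of the chain

This account rests on a few compounds, and the source may have more. Where it says the series, first, only, none or still open, it means among the compounds named here.

In a functional assay on MCF7 cells (Homo sapiens) for antiproliferative activity (on this read-out higher numbers stand for weaker inhibition and lower numbers for stronger inhibition), compound 1 (`CC(C)=CCc1cc(C(=O)Nc2cc3ccc(OCC4CCCNC4)c(C)c3oc2=O)ccc1O`) gives 790 nM and compound 2 (`CC(C)=CCc1cc(C(=O)Nc2cc3ccc(OCCCNCC(N)=O)c(C)c3oc2=O)ccc1O`) gives 1460 nM while compound 3 (`CC(C)=CCc1cc(C(=O)Nc2cc3ccc(OCCCNCCO)c(C)c3oc2=O)ccc1O`) gives 1560 nM on the same read-out. Compound 3 therefore stands within the scatter of both other compounds. Compound 4 (`CC(C)=CCc1cc(C(=O)Nc2cc3ccc(OCCCN(C)c4ccccc4)c(C)c3oc2=O)ccc1O`) has methyl(phenyl)amino in place of (2-hydroxyethyl)amino on a saturated chain carbon, three bonds along the chain from an oxygen on an aromatic ring and remains unmeasured. For the measured compounds named here, three measured steps bear on this change, namely a 1.8-fold higher number from compound 1 to compound 2 (0.27 log units; within the scatter) and a 2.0-fold higher number from compound 1 to compound 3 (0.30 log units; within the scatter) and a 1.1-fold higher number from compound 2 to compound 3 (0.03 log units; within the scatter) and each stays within the scatter. None of the three measured compounds carries methyl(phenyl)amino, so these steps are only a loose guide. On the strength of those small steps, no change beyond the scatter is expected in this assay for this replacement. The estimated step is a 1.2-fold lower number from compound 3 to compound 4 (0.08 log units; within the scatter) and it stays within the scatter. Compound 4 is estimated at 1300 nM with 450 nM to 3800 nM as the expected range.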

Compound 4, half-maximal inhibitory concentration: > 50000 nM
Compound 4 gave a limit, no number; the forecaster's own chance of this, stated with the estimate: 4%; middle value at least 38-fold (1.58 log units) from the limit.
By their numbers in this assay, from the lowest: compounds 1, 2 and 3 (each within the scatter of the next). At a limit, above all of these: compound 4.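

In this assay, compound 4 gives a limit and not a number: the limit of > 50000 nM in this assay, at which 1 of the 4 values shown sits.

Read against that limit, the replacement of (2-hydroxyethyl)amino by methyl(phenyl)amino gives an at least 32-fold higher number from compound 3 to compound 4 (1.50 log units; beyond the scatter), and the other two comparisons give an at least 34-fold higher number from compound 2 to compound 4 (1.53 log units; beyond the scatter) and an at least 63-fold higher number from compound 1 to compound 4 (1.80 log units; beyond the scatter). The earlier compounds shown here, with piperidin-3-yl, (carbamoylmethyl)amino and (2-hydroxyethyl)amino ends, stayed within the scatter of each other, whereas this position clearly does not tolerate every group on the saturated chain.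

The compounds shown do not tell whether the six-membered aromatic ring or the methyl on the nitrogen goes with this loss of activity. A phenylamino or a dimethylamino group at the same place would separate the two.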